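The source may report more compounds than this note shows. Statements on the series, on what has been measured and on what is new or still open speak of the compounds shown alone.

In an assay for inhibition of Indoleamine 2,3-dioxygenase 1 (Homo sapiens), read by spectrophotometry, with a stated time of 180 min, tested at 10 uM (a lower number here means a weaker effect, a higher number a stronger effect of the compound at the concentration tested), compound 1 `Brc1cc(NCc2ccccc2)c2cn[nH]c2c1` gives 37%, and compound 2 `Cc1ccc(CNc2cc(Br)cc3[nH]ncc23)cc1` gives 20%. The two share a core and differ in one place, (hydrogen in place of methyl on an aromatic carbon), which made the step of a number 17 percentage points higher from compound 2 to compound 1 (beyond the scatter). Compound 3 `Cc1nc(NCc2ccc(C(=O)O)cc2)c2cn[nH]c2n1` is built on another core; the difference between the two cores is not broken down here. In this assay compound 3 gives 5%, the lowest of the three numbers. Compound 4 `O=C(O)c1ccc(CNc2ncnc3[nH]ncc23)cc1` is not yet measured and differs from compound 3 by hydrogen in place of methyl on an aromatic carbon. Going by the values given here, this is the same kind of change as the one from compound 2 to compound 1, but not the same: there the place was on a six-membered aromatic ring of carbon only, para to a large group, whereas here it is on a six-membered aromatic ring with 2 nitrogen, part of a fused or bridged system of two rings, between two ring nitrogen atoms. Given the different surroundings, a smaller step than a number 17 percentage points higher from compound 2 to compound 1 (beyond the scatter) is expected. For compound 4 the expected step is a number 9 percentage points higher from compound 3 to compound 4 (within the scatter), resting on compound 3 with 5%. Compound 4 is estimated at 14%, likely within 0% to 32% in this assay.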

Compound 4, a percentage reported as inhibition, at one concentration (the size of the read-out at that concentration, not a potency): 3%
Estimate against measurement, compound 4: 11 percentage points above; measured number inside the range.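

In this assay, putting hydrogen in place of methyl on the carbon between two ring nitrogen atoms gives a number 2 percentage points lower from compound 3 to compound 4 (within the scatter), so on this core the change has no effect that can be told apart from the usual scatter. Set beside the earlier step, the same change does not carry over from one core to the other with the same result: the same change on two cores in this assay, a number 17 percentage points higher (beyond the scatter) from compound 2 to compound 1 and a number 2 percentage points lower (within the scatter) from compound 3 to compound 4, 19 percentage points apart, beyond the scatter of two such steps. This shows that a gain seen on one core cannot be assumed on the other in this series, but it does not show why the two steps differ, and two pairs of compounds give no general rule.

The compounds shown leave open how an amine or a longer chain such as ethyl would behave at this carbon on the core of compound 3. They also leave open whether the carboxylic acid, present in compound 3 and compound 4 but absent from compound 1 and compound 2, plays any part in the different outcomes.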